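The source may report more compounds than this note shows. Statements on the series, on what has been measured and on what is new or still open speak of the compounds shown alone.

Measured in a physicochemical assay for solubility, read by HPLC, in phosphate buffer, with a stated time of 16 h, at pH 6.8; on this read-out lower numbers stand for lower solubility and higher numbers for higher solubility:

- compound 1, `Cc1ccc([C@H](C)NC(=O)Cn2nnc3ccccc3c2=O)c(C)c1`, gives 2700 nM
- compound 2, `COc1cc(C)ccc1[C@H](C)NC(=O)Cn1nnc2ccccc2c1=O`, gives 6900 nM
- compound 3, `COc1ccc2nnn(CC(=O)N[C@@H](C)c3ccc(C)cc3)c(=O)c2c1`, gives 2300 nM

Compound 2 and compound 1 differ in one place: methyl in place of methoxy on an aromatic carbon. That single change made a step of a 2.6-fold lower number from compound 2 to compound 1 (0.41 log units; beyond the scatter), a modest drop that goes beyond the usual scatter of this assay.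

Compound 3 has the same atoms as compound 2 but joined differently, so the two cores are not the same; the difference between the two cores is not broken down here. Compound 3 and compound 1 sit within the scatter of each other, so nothing can be said about which of the two is the more soluble.

Compound 4, `Cc1ccc([C@H](C)NC(=O)Cn2nnc3ccc(C)cc3c2=O)cc1`, has not yet been measured. It differs from compound 3 by methyl in place of methoxy on an aromatic carbon. Among the compounds with values here, this is the same kind of change as the one from compound 2 to compound 1, not the same: there the change sat on a six-membered aromatic ring of carbon only, ortho to a large group and meta to a methyl group, whereas here it sits on a ring that is part of a fused or bridged system of two rings, meta to a fused ring and para to a fused ring. The surroundings therefore differ, and only one earlier example of this change exists among these compounds.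

For compound 4 the expected step is a 2.6-fold lower number from compound 3 to compound 4 (0.41 log units; beyond the scatter), resting on the earlier change from compound 2 to compound 1, which gave a 2.6-fold lower number from compound 2 to compound 1 (0.41 log units; beyond the scatter). Compound 4 is thus estimated at 900 nM, with a likely range of 350 nM to 2500 nM.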

Compound 4, solubility: 3100 nM
Compound 4: middle estimate off by 3.4-fold (0.54 log units), on the low side, outside the stated range (above it).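

In this assay, methyl in place of methoxy on the core of compound 3 gave a small step (a 1.3-fold higher number from compound 3 to compound 4 (0.13 log units; within the scatter)), which leaves the two compounds indistinguishable, whereas the same kind of change on the core of compound 2 gave a clear one (a 2.6-fold lower number from compound 2 to compound 1 (0.41 log units; beyond the scatter)). The drop seen on one core therefore did not carry over to the other, so in this series a step taken from one core is a weak guide to the same change on another, even when the groups that leave and enter are identical. With only these two examples, this gives no rule for a further core, and it does not show why the two results part, since nothing available here bears on the cause.

The compounds shown leave open whether methyl in place of methoxy would follow either result on a third core, or at another place on these two. They also leave open how quite different groups would read at this aromatic carbon on the core of compound 3, such as an amine, a carboxylic acid or a longer chain.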